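The compounds below may be only part of what the source reports. "The series", "measured", "known", "first", "only" and "open" are said of these compounds alone.

Compound 1, `Cc1ncc(-c2ccccc2NCC2=NCCN2)o1`, in a functional assay for activation of Alpha-1D adrenergic receptor (Homo sapiens) (on this read-out lower numbers stand for an effect already at smaller amounts and higher numbers for an effect only at larger amounts of compound), gives the assay's limit < 5020 nM.
Compound 2, `c1csc(-c2ccccc2NCC2=NCCN2)c1`, in this assay gives 18.2 nM.
Compound 3, `Cc1noc(-c2ccccc2NCC2=NCCN2)n1`, in this assay gives the assay's limit < 5020 nM.

Compound 3 therefore stands in this assay not on a number but on a limit, and it shares that position with another value: the limit of < 5020 nM in this assay, at which 2 of the 3 values shown sit. The three measured steps among these compounds all involve at least one limit, so their sizes cannot be read: a step that the limit leaves unreadable from compound 1 to compound 2, a step that the two limits leave unreadable from compound 1 to compound 3, a step that the limit leaves unreadable from compound 2 to compound 3. Only compound 2 gives a true number, so the measured data set a frame rather than a direction.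

Compound 4, `CO/N=C(\C)c1ccccc1NCC1=NCCN1`, differs from compound 3 at one place: a group of 5 heavy atoms (3 carbon, 1 nitrogen, 1 oxygen; no ring) in place of a group of 6 heavy atoms (3 carbon, 2 nitrogen, 1 oxygen; one five-membered aromatic ring with 3 hetero atoms), on an aromatic carbon. Among the measured compounds shown here, no measured step removes a ring from this position, so none of the measured steps speaks directly to the change; they show only that a five-membered aromatic ring at this place can give either a number or a limit in this assay. With that frame, the step from compound 3 to compound 4 is expected to fall roughly as a step that the limit leaves unreadable from compound 3 to compound 4, with wide uncertainty. For compound 4 the expected value in this assay is 600 nM, estimated to lie between 40 nM and 5000 nM.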

Compound 4, half-maximal effective concentration: < 5020 nM
Compound 4 was reported as a limit; the forecaster's own chance of this, stated with the estimate: 30%; the middle value lies beyond the limit too.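

In this assay compound 4 gives < 5020 nM, which is a limit and not a number. None of its steps from compound 1, compound 2 or compound 3 can be read, and it joins the other limits: the limit of < 5020 nM in this assay, at which 3 of the 4 values shown sit. Left open is how far compound 1, compound 3 and compound 4 lie from compound 2, the only one with a true number.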